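Lengthening the Chain from Compound 3 to Compound 4

A few compounds are considered here, and "the series" means these few. Any claim that something is new, unique, unknown or untested is made for them only; others in the source may bear on it.

Compound 1 `CCCCCCCCCCCCCCOc1cc(OC)c(Br)cc1C(C)=O`: 16100000 nM
Compound 2 `CCCCOc1cc(OC)ccc1C(C)=O`: 43300000 nM
Compound 3 `CCCCCCCCOc1cc(OC)ccc1C(C)=O`: 40000000 nM

All three values come from a functional assay, with a stated time of 30 min; a higher number here means a weaker inhibitor, a lower number a stronger inhibitor. Compound 3 stands level with compound 2 within the scatter, while compound 1 shows a lower number than compound 3, a gap beyond the scatter.

Compound 4 `CCCCCCCCCCCCCCOc1cc(OC)ccc1C(C)=O` has not yet been measured. It extends the chain of compound 3: hexyl in place of hydrogen on a saturated chain carbon, eight bonds along the chain from an oxygen on an aromatic ring, that is, hexyl in place of hydrogen on a saturated chain carbon.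

Among the compounds with values here, only one measured step is of the same kind, a butyl extension of the chain. It amounted to a 1.1-fold lower number from compound 2 to compound 3 (0.03 log units; within the scatter), so chain growth has so far brought no change beyond the scatter. The chain of compound 4 also appears in compound 1, which carries an extra bromine on the shared core. Compound 1 gives 16100000 nM, a loose hint towards a lower number, since the data do not separate the chain from the bromine. A small drop in this assay is therefore expected, probably no larger than the scatter. The expected change is a 1.3-fold lower number from compound 3 to compound 4 (0.12 log units; within the scatter). For compound 4 the estimated value is 30000000 nM, with an expected range of 13000000 nM to 60000000 nM.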

Compound 4, half-maximal inhibitory concentration: 43600000 nM
The estimate for compound 4 lay 1.5-fold (0.16 log units) below the measured number, within the range that was stated.
By their numbers in this assay, from the lowest: compound 1; then compounds 3, 2 and 4 (each within the scatter of the next).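

In this assay, the hexyl extension gave a 1.1-fold higher number from compound 3 to compound 4 (0.04 log units; within the scatter), and the earlier butyl extension gave a 1.1-fold lower number from compound 2 to compound 3 (0.03 log units; within the scatter); across compounds 2, 3 and 4, therefore, lengthening this chain moves the number by no more than the scatter. Compound 4 also settles what compound 1 alone could not, since the two share the same chain and differ in one place: hydrogen in place of bromo on an aromatic carbon gave a 2.7-fold higher number from compound 1 to compound 4 (0.43 log units; beyond the scatter), a modest step beyond the scatter, so the lower number of compound 1 goes with the bromo group rather than with the chain. No independent evidence accounts for either the flat response to chain length or the step at the aromatic carbon.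

The compounds shown leave open whether bromo would give a step of similar size on the shorter chains of compound 2 or compound 3, and whether chloro or another halogen at that aromatic carbon would do the same. They also leave open whether an amine or a carboxylic acid at the end of the chain would move the number where added carbons did not.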